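Isopropyl for methyl on the chain carbon

The compounds below may be only part of what the source reports. "The series", "measured", "known", "first", "only" and "open" are said of these compounds alone.

In a physicochemical assay for lipophilicity (on this read-out higher numbers stand for higher lipophilicity and lower numbers for lower lipophilicity), compound 3 (`Cc1nc(C)c(COC(=O)N[C@H](C)C(=O)Oc2ccc(-c3cc(=O)c4c(O)c(O)c(O)cc4o3)cc2)nc1C`) gives 1.53 and holds the middle of the three measured numbers only loosely. Compound 1 (`Cc1nc(C)c(C(=O)N[C@@H](C(=O)Oc2ccc(-c3cc(=O)c4c(O)c(O)c(O)cc4o3)cc2)C(C)C)nc1C`) at 1.38 lies within the scatter of compound 3, while compound 2 (`Cc1nc(C)c(COC(=O)NCC(=O)Oc2ccc(-c3cc(=O)c4c(O)c(O)c(O)cc4o3)cc2)nc1C`) at 2.1 stands beyond the scatter above it. Compound 4 (`Cc1nc(C)c(COC(=O)N[C@@H](C(=O)Oc2ccc(-c3cc(=O)c4c(O)c(O)c(O)cc4o3)cc2)C(C)C)nc1C`) carries isopropyl in place of methyl on a saturated chain carbon bound to an amide-type nitrogen and a carbonyl carbon. Within the data shown here, only one measured step bears on this, methyl in place of hydrogen at the same carbon, and with that modest a number 0.57 log units lower from compound 2 to compound 3 (beyond the scatter) as the sole guide no step beyond the scatter is expected in this assay in either direction. Compound 1 also carries isopropyl on that carbon, and its 1.38 offers a loose anchor for the estimate. The expected change is a number 0.17 log units higher from compound 3 to compound 4 (within the scatter) and no more. For compound 4 the estimated value is 1.7 with an expected range from 1.2 to 2.2 as its bounds.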

Compound 4, partition coefficient: 1.04
For compound 4 the middle estimate is 0.66 log units above the measured one; the measured number lies below the stated range.
By their numbers in this assay, from the lowest: compound 4; then compounds 1 and 3 (each within the scatter of the next); then compound 2.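

At the saturated chain carbon bound to an amide-type nitrogen and a carbonyl carbon, the fall in this assay seen with methyl in place of hydrogen continues with the larger group: isopropyl in place of methyl gives a number 0.49 log units lower from compound 3 to compound 4 (beyond the scatter) and isopropyl in place of hydrogen gives a number 1.06 log units lower from compound 2 to compound 4 (beyond the scatter), so the number drops at each step across these three compounds as carbon is added. Among these compounds, with isopropyl held on that carbon, (3,5,6-trimethylpyrazin-2-yl)methoxy in place of 3,5,6-trimethylpyrazin-2-yl on a carbonyl carbon gives a number 0.34 log units lower from compound 1 to compound 4 (beyond the scatter), the first reading of that change. Nothing at hand explains the direction of these steps.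

From the compounds shown here alone, whether the fall continues with a tert-butyl or benzyl group on that chain carbon remains open, as does the effect of an amine or a carboxylic acid there. Going by these compounds, whether the change on the carbonyl carbon keeps its direction with hydrogen or methyl on the chain carbon is also open.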